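A few compounds are considered here, and "the series" means these few. Any claim that something is new, unique, unknown or untested is made for them only; others in the source may bear on it.

Working notes on the series. Compound 1 `Cc1c(O)ccc2c1[C@H](Cn1cc(-c3ccc(F)cc3)nn1)[C@@]13CC(=O)[C@@](C)(CC[C@@H]21)C3` and compound 2 `Cc1c(O)ccc2c1[C@H](Cn1cc(-c3ccccn3)nn1)[C@@]13CC(=O)[C@@](C)(CC[C@@H]21)C3` share one core; compound 3 `C=C1C[C@]23C[C@@]1(O)CC[C@H]2c1cc(Br)c(O)c(C)c1[C@@H]3Cn1cc(-c2ccc(F)cc2)nn1` and compound 4 `C=C1C[C@]23C[C@@]1(O)CC[C@H]2c1cc(Br)c(O)c(C)c1[C@@H]3Cn1cc(-c2ccccn2)nn1` share a second, and the difference between the two cores is not broken down here. In a functional assay on MCF7 cells (Homo sapiens) for cytotoxicity, read by MTT assay, with a stated time of 4 days (a lower number here means a stronger inhibitor, a higher number a weaker inhibitor), compound 1 gives only a limit, > 20000 nM. In this assay compound 2 also gives only a limit, > 20000 nM. The change between them, (pyridin-2-yl in place of 4-fluorophenyl on an aromatic carbon), therefore made a step that the two limits leave unreadable from compound 1 to compound 2. In this assay, within the data shown here, compound 3 gives 19200 nM, the single number among the three measured compounds. Compound 4 carries the same change on the second core, (pyridin-2-yl in place of 4-fluorophenyl on an aromatic carbon). Because the limit of > 20000 nM in this assay, at which 2 of the 3 values shown sit, holds both compounds of the first pair, the earlier step offers no readable size. The expected step is a 1.1-fold higher number from compound 3 to compound 4 (0.06 log units; within the scatter), i.e. weak activity carried over. Compound 4 is estimated at 22000 nM in this assay, within 9000 nM to 60000 nM.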

Compound 4, half-maximal inhibitory concentration: > 20000 nM
Compound 4 was reported as a limit; the forecaster's own chance of this, stated with the estimate: 60%; the middle value lies beyond the limit too.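

In this assay the change from 4-fluorophenyl to pyridin-2-yl on the second core made an at least 1.0-fold higher number from compound 3 to compound 4 (0.01 log units; that floor lies within the scatter). Compound 4 gives only a limit, > 20000 nM. So neither core shows a readable gain from this change, but the step on the first core cannot be read and the step on the second is only a floor, so it is not shown whether the change has the same size on both cores, because most values sit at one limit: the limit of > 20000 nM in this assay, at which 3 of the 4 values shown sit.

Open, on these data alone, is whether an amine, a carboxylic acid or a longer chain on that same aromatic carbon would give a number clear of this limit in this assay. Only such a number would allow a step to be compared between the two cores.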